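Methylating a phenol in a diarylurea series

A few compounds are considered here, and "the series" means these few. Any claim that something is new, unique, unknown or untested is made for them only; others in the source may bear on it.

Measured so far:
compound 1, `O=C(Nc1cccc(-n2cc(-c3ccncc3)c(-c3cc(O)cc(Cl)c3)n2)c1)Nc1ccc(Cl)c(C(F)(F)F)c1`: 77%
compound 2, `O=C(Nc1cccc(-n2cc(-c3ccncc3)c(-c3cc(O)cc(Cl)c3)n2)c1)Nc1ccc(Cl)c(Cl)c1`: 50%

In a functional assay on MDA-MB-231 cells (Homo sapiens) for inhibition, read by sulforhodamine B assay, with a stated time of 48 h, tested at 1 uM (on this read-out higher numbers stand for a weaker effect at the one concentration tested and lower numbers for a stronger effect), compound 1 gives the higher of the two numbers, and compound 2 sits apart from it, since a number 27 percentage points lower from compound 1 to compound 2 (beyond the scatter). Among the compounds with values here, that step concerns the distal aryl ring of the urea, where chloro replaces trifluoromethyl; it is the only step recorded, and it touches nothing on the hydroxyphenyl side of the shared core.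

Compound 3, `COc1cc(Cl)cc(-c2nn(-c3cccc(NC(=O)Nc4ccc(Cl)c(C(F)(F)F)c4)c3)cc2-c2ccncc2)c1`, is not yet measured. It departs from compound 1 at a different place: methyl in place of hydrogen on an oxygen on an aromatic ring. Within the data shown here, no measured pair in this set changes that oxygen, so nothing here tells how this assay answers to it; the one recorded step bears on another part of the molecule and cannot be read across.

Among the measured compounds shown here, with no step to lean on, compound 3 is expected to stay near the starting point, and a number 3 percentage points higher from compound 1 to compound 3 (within the scatter) is expected to lie within the scatter, in no particular direction. From the compounds shown here alone, the estimate for compound 3 is therefore 80%, with a range from 55% to 100%; the range is wide, as this part of the structure is untested.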

Compound 3, a percentage reported as activity, at one concentration (the size of the read-out at that concentration, not a potency): 69%
Estimate against measurement, compound 3: 11 percentage points above; low and high end bracket the measured number.
By their numbers in this assay, from the lowest: compound 2; then compounds 3 and 1 (each within the scatter of the next).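

Within the data shown here, replacing 3-chloro-5-hydroxyphenyl with 3-chloro-5-methoxyphenyl gives the first reading at this position, and in this assay the change amounts to a number 8 percentage points lower from compound 1 to compound 3 (within the scatter) on the trifluoromethyl side of the urea. The hydrogen on this oxygen can therefore give way to methyl with no result that stands apart from the scatter, so a free hydroxy is not shown to be needed for the read-out at this single concentration. Nothing available explains this outcome or connects it to any measured property of the two compounds.

The compounds shown leave open whether the same tolerance extends to other replacements at this oxygen or on this carbon, such as an ethoxy group, a longer alkoxy chain, an amine or a carboxylic acid, since methyl is the only change tested here. They also leave open whether methoxy would behave the same way alongside the dichlorophenyl urea of compound 2, and how compound 1 and compound 3 would compare across a range of concentrations rather than at the single one used.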